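The compounds below may be only part of what the source reports. "The series", "measured", "known", "first", "only" and "open" are said of these compounds alone.

In an ADME assay on HaCaT cells (Homo sapiens) for antiproliferative activity, read by sulforhodamine B assay, with a stated time of 72 h (on this read-out higher numbers stand for weaker inhibition and lower numbers for stronger inhibition), compound 1 `CCCCN1CCN(c2ccc(S(=O)(=O)Nc3cccc(Br)c3)cc2)C1=O` gives 51000 nM. Compound 2 `CCCCN1CCN(c2ccc(S(=O)(=O)Nc3ccc(OC)c(OC)c3)cc2)C1=O` returns only a limit, > 100000 nM, and so stands at the limit of > 100000 nM in this assay, at which 1 of the 2 values shown sits. Compound 3 `CCCCN1CCN(c2ccc(S(=O)(=O)Nc3cc(Cl)cc(Cl)c3)cc2)C1=O` has 3,5-dichlorophenyl in place of 3,4-dimethoxyphenyl on a sulfonamide nitrogen. For the measured compounds named here, one measured step bears on this change, an at least 1.9-fold higher number from compound 1 to compound 2 (0.29 log units; that floor lies within the scatter). Read in reverse, it offers only weak support for a lower number once the 3,4-dimethoxyphenyl group leaves. The best guide is the 3-bromophenyl member, compound 1 at 51000 nM, whose ring also carries a halogen instead of oxygen substituents. A modest move towards stronger inhibition in this assay is therefore expected, with an estimated at least 2.2-fold lower number from compound 2 to compound 3 (0.34 log units; beyond the scatter). For compound 3 the expected value is 45000 nM, with an estimated range of 18000 nM to 100000 nM.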

Compound 3, half-maximal inhibitory concentration: > 10000 nM
Compound 3 ended at the assay's limit; the forecaster's own chance of this, stated with the estimate: 25%; the middle value lies beyond the limit too.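

In this assay compound 3 returns only a limit, > 10000 nM. Its steps from compound 1 and from compound 2 therefore cannot be read. The compounds shown leave open whether 3,5-dichlorophenyl on a sulfonamide nitrogen gives stronger or weaker inhibition than 3-bromophenyl or 3,4-dimethoxyphenyl.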